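Second chloro on the core of compound 1

This account rests on a few compounds, and the source may have more. Where it says the series, first, only, none or still open, it means among the compounds named here.

Within the data shown here, compound 1, `ClCc1ccc(Cn2cnc3c(Cl)ncnc32)cc1`, gives the lowest number of the three measured so far in a functional assay on NCI-H23 cells (Homo sapiens) for cytotoxicity, read by sulforhodamine B assay, with a stated time of 48 h (on this read-out higher numbers stand for weaker inhibition of growth and lower numbers for stronger inhibition of growth), with 660 nM. Compound 2, `ClCc1ccc(Cn2cnc3nc(Cl)nc(Cl)c32)cc1`, gives 2340 nM in this assay, a number beyond the scatter from compound 1. Compound 3, `ClCc1ccccc1Cn1cnc2ncnc(Cl)c21`, gives 5010 nM, the highest of the set and the furthest from compound 1. Among the measured compounds shown here, no single-point step between measured compounds exists in this set, so no measured step size is available to lean on.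

Compound 4, `ClCc1ccc(Cn2cnc3c(Cl)nc(Cl)nc32)cc1`, is not yet measured. It differs from compound 1 by chloro in place of hydrogen on an aromatic carbon. Compound 2 also carries two chloro groups on its core and gives a higher number than compound 1, but its core arrangement differs from that of compound 4 in more than one place, so it offers only a loose hint.

In this assay the step from compound 1 to compound 4 is expected to be small, toward a somewhat higher number, and may not exceed the scatter, giving a 1.5-fold higher number from compound 1 to compound 4 (0.18 log units; within the scatter). Compound 4 is therefore expected to give about 1000 nM in this assay, within a range from 400 nM to 3000 nM.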

Compound 4, concentration for 50% growth inhibition: 7590 nM
Estimate against measurement, compound 4: 7.6-fold (0.88 log units) below; the whole stated range lies below it.
By their numbers in this assay, from the lowest: compound 1; then compound 2; then compounds 3 and 4 (each within the scatter of the next).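

Among these compounds, the step at this position, a 12-fold higher number from compound 1 to compound 4 (1.06 log units; beyond the scatter), is the first single-point change that can be read in this assay, since the earlier compounds differed from one another in more than one place. It shows that this aromatic carbon, between two ring nitrogen atoms on the six-membered aromatic ring with 2 nitrogen, is not a silent site: one added heavy atom, chloro in place of hydrogen, is enough to give a large move toward weaker inhibition of growth. Among the compounds shown here, no measurement at hand bears on why the step is this large, and the single pair gives no basis for a wider rule about this position.

Going by these compounds, only hydrogen and chloro are compared on this carbon, so it remains open whether a fluoro, a methyl, a methoxy or an amine there would stay close to compound 1 or move as far as compound 4. On these data alone, it also remains open whether the same chloro change would give a step of similar size on compound 3, where the chloromethyl group is placed differently.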